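Cytotoxicity notes on an oxazolylmethyl-piperidine ketone series

The source may report more compounds than this note shows. Statements on the series, on what has been measured and on what is new or still open speak of the compounds shown alone.

Measured so far:
Compound 1, `O=C(c1ccc2c(c1)OCCO2)C1CCN(Cc2coc(-c3ccc(Br)cc3)n2)CC1`. In an ADME assay on HEK293 cells (Homo sapiens) for cytotoxicity, read by MTT assay, with a stated time of 36 h (on this read-out lower numbers stand for stronger inhibition and higher numbers for weaker inhibition), compound 1 gives > 150 ug/mL, which is a limit of the assay and not a number.
Compound 2, `O=C(c1ccc2c(c1)CCCC2)C1CCN(Cc2coc(-c3ccc(F)cc3)n2)CC1`. In this assay compound 2 gives > 150 ug/mL, again a limit of the assay.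
Compound 3, `O=C(c1ccccc1)C1CCN(Cc2coc(-c3ccc(F)cc3)n2)CC1`. In this assay compound 3 gives > 150 ug/mL, likewise a limit of the assay.

Compound 3 therefore stands at the limit of > 150 ug/mL in this assay, at which 3 of the 3 values shown sit; no numerical cytotoxicity is available for it or for either of its companions. Going by the values given here, the one single-point step among the measured compounds, a step that the two limits leave unreadable from compound 2 to compound 3, cannot be sized, since both ends are limits.

Compound 4, `COc1ccc(C(=O)C2CCN(Cc3coc(-c4ccc(F)cc4)n3)CC2)cc1OC`, differs from compound 3 in one place: 3,4-dimethoxyphenyl in place of phenyl on a carbonyl carbon. Among the compounds with values here, the only measured step that bears on this change is the one from compound 2 to compound 3, which is unreadable in size, so there is no evidence for a shift in either direction beyond the usual scatter in this assay.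

On that basis compound 4 is expected to remain at the limit, estimated as 180 ug/mL with a range of 100 ug/mL to 400 ug/mL. The expected step is a step that the limit leaves unreadable from compound 3 to compound 4, taken as no change beyond the scatter.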

Compound 4, half-maximal inhibitory concentration: > 150 ug/mL
Compound 4 ended at the assay's limit (the forecaster's own chance of this, stated with the estimate: 85%); the middle value lies beyond the limit too.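

No step can be read from compound 3 to compound 4 or from compound 2 to compound 4, because each end of both pairs is a limit of the assay and not a number: the limit of > 150 ug/mL in this assay, at which 4 of the 4 values shown sit. The compounds shown leave open whether any group on the carbonyl carbon changes the result in this assay.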